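This account rests on a few compounds, and the source may have more. Where it says the series, first, only, none or still open, it means among the compounds named here.

Measured so far:
- compound 1 `O=C1CCc2c1c1c(c3c2[nH]c2ccccc23)C(=O)NC1=O`: 16100 nM
- compound 2 `O=C1NC(=O)c2c1c1c(O)cccc1c1[nH]c3ccccc3c21`: 46400 nM
- compound 3 `O=c1ccc(=O)c2c1c1[nH]c3ccccc3c1c1c(=O)[nH]c(=O)c21`: 17400 nM

All three compounds were tested in a functional assay on HT-29 cells (Homo sapiens) for antiproliferative activity, with a stated time of 4 h; on this read-out lower numbers stand for stronger inhibition and higher numbers for weaker inhibition. Compound 3, at 17400 nM, cannot be told apart from compound 1, at 16100 nM, since the gap between them lies within the scatter of repeated measurements. Compound 2, at 46400 nM, gives a higher number and so weaker inhibition, and its gap to compound 3 lies beyond the scatter.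

The next compound, compound 4 `Cc1ccc2[nH]c3c4c(=O)ccc(=O)c4c4c(=O)[nH]c(=O)c4c3c2c1`, differs from compound 3 in one place: methyl in place of hydrogen on an aromatic carbon. A methyl takes the place of a hydrogen on an aromatic carbon of a six-membered aromatic ring of carbon only. For the measured compounds named here, no two measured compounds differ in just one place, so the data offer no direct guide to this change. With no such guide, no step beyond the scatter is expected in this assay, in either direction. The expected step is small: a 1.2-fold lower number from compound 3 to compound 4 (0.06 log units; within the scatter), an estimate within the scatter. Compound 4 is estimated at 15000 nM, with an expected range of 6000 nM to 40000 nM.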

Compound 4, half-maximal inhibitory concentration: 20600 nM
For compound 4 the middle estimate is 1.4-fold (0.14 log units) below the measured one; low and high end bracket the measured number.
By their numbers in this assay, from the lowest: compounds 1, 3 and 4 (each within the scatter of the next); then compound 2.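

For the compounds shown here, compound 3 and compound 4 are the first pair here that differ in just one place, so they give the first direct reading of any single change. In this assay, putting methyl in place of hydrogen on this aromatic carbon gives a 1.2-fold higher number from compound 3 to compound 4 (0.07 log units; within the scatter), which means that this position of the shared core can carry a methyl with no measurable effect on this read-out. No measurement available here explains this result.

From the compounds shown here alone, a single methyl says little about other groups, so it remains open whether an ethyl chain, an amine or a carboxylic acid on the same carbon would also leave the number within the scatter. Going by these compounds, it is also open whether a methyl on another aromatic carbon of the core would give the same result.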